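Terminal-chain variation at the pendant phenyl ring

A few compounds are considered here, and "the series" means these few. Any claim that something is new, unique, unknown or untested is made for them only; others in the source may bear on it.

Of the compounds shown here, two have been measured in a functional assay on blood for antagonist activity at thromboxane A2 receptor (Homo sapiens); on this read-out lower numbers stand for tighter binding and higher numbers for weaker binding. Compound 1 `CC(=O)NCc1ccccc1-c1ccc(COC2CC[C@H](N3CCCCCC3)[C@H]2OC/C=C\CCC(=O)O)cc1` gives 25.1 nM, the highest number of the two. Compound 2 `O=C(O)CC/C=C\CO[C@H]1[C@@H](OCc2ccc(-c3ccccc3CO)cc2)CC[C@@H]1N1CCCCCC1` gives 1.59 nM, a lower number; the gap between compound 1 and compound 2 lies beyond the scatter, so the two values cannot be read as equivalent. For the measured compounds named here, no step between these two is worked out, and their difference is not described further here.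

Compound 3 `O=C(O)CC/C=C\CO[C@H]1C(OCc2ccc(-c3ccccc3CCO)cc2)CC[C@@H]1N1CCCCCC1` remains to be measured in this assay. Relative to compound 1 the change is hydroxymethyl in place of acetamido on a saturated chain carbon bound to an aromatic carbon. Compound 1 carries the acetamidomethyl group and stands at the weaker end, while compound 2, which carries a hydroxymethyl group, gives 1.59 nM; on that basis a step down toward tighter binding is expected for compound 3, and beyond the scatter. The expected step is a 7.8-fold lower number from compound 1 to compound 3 (0.89 log units; beyond the scatter). Compound 3 is estimated at 3.2 nM, in the range 0.8 nM to 13 nM.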

Compound 3, dissociation constant: 2 nM
Estimate against measurement, compound 3: 1.6-fold (0.20 log units) above, within the range that was stated.
By their numbers in this assay, from the lowest: compounds 2 and 3 (each within the scatter of the next); then compound 1.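

In this assay the exchange of acetamido for hydroxymethyl on a saturated chain carbon bound to an aromatic carbon gives a 13-fold lower number from compound 1 to compound 3 (1.10 log units; beyond the scatter) and shows that this position responds strongly to the group it carries. Compound 2 at 1.59 nM and compound 3 at 2 nM lie within the scatter of each other, so the hydroxymethyl and 2-hydroxyethyl chains give matching values, and only compound 1 stands apart from them. No measured evidence bears on the cause of this step.

Going by these compounds, whether a primary amine or a carboxylic acid at the end of the 2-hydroxyethyl chain would keep the value of compound 3 remains open. On these data alone, a 3-hydroxypropyl chain, which would show how far the hydroxyl can move along the chain, also remains open.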